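The compounds below may be only part of what the source reports. "The series", "measured", "known", "first", "only" and "open" are said of these compounds alone.

Compound 1 `O=C1C=C(N2CCC2)C(=O)c2c1nc1n2[C@H]2OC[C@@H](O)[C@H]2OC1`: > 16000 nM (a limit)
Compound 2 `O=C1C=C(Nc2ccccc2F)C(=O)c2c1nc1n2[C@H]2OC[C@@H](O)[C@H]2OC1`: 2760 nM

Both results come from a functional assay on ECa-109 cells for inhibition, with ECa-109 cell line (Homo sapiens) as the target, read by sulforhodamine B assay; a lower number here means a stronger inhibitor, a higher number a weaker inhibitor. Among the compounds with values here, compound 2 holds the only exact number so far, 2760 nM. The result for compound 1 is only a limit.

Compound 3 `O=C1C=C(NC2CCCCC2)C(=O)c2c1nc1n2[C@H]2OC[C@@H](O)[C@H]2OC1` keeps the shared core and changes one group: cyclohexyl in place of 2-fluorophenyl on an amine nitrogen. In words, cyclohexyl stands in place of 2-fluorophenyl on an amine nitrogen, so (2-fluorophenyl)amino becomes cyclohexylamino. An aromatic ring gives way to a non-aromatic one.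

Within the data shown here, only one measured step bears on this change: an at least 5.7-fold lower number from compound 1 to compound 2 (0.76 log units; beyond the scatter). That step replaced azetidin-1-yl with (2-fluorophenyl)amino on the double-bonded ring carbon, which brought in the aromatic ring. Removing that aromatic ring in compound 3 therefore points to a move back toward weaker inhibition in this assay. The move is expected to be modest, since a six-membered ring stays in place and this single comparison is thin evidence.

The estimated step is a 2.2-fold higher number from compound 2 to compound 3 (0.34 log units; beyond the scatter), toward a higher number. For compound 3 the expected value is 6000 nM. The estimated range runs from 1800 nM to 16000 nM.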

Compound 3, half-maximal inhibitory concentration: > 16000 nM
Compound 3 ended at the assay's limit; the forecaster's own chance of this, stated with the estimate: 20%; middle value at least 2.6-fold (0.42 log units) away from the limit.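

In this assay, putting cyclohexyl in place of 2-fluorophenyl on the amine nitrogen gives an at least 5.7-fold higher number from compound 2 to compound 3 (0.76 log units; beyond the scatter). The earlier step exchanged azetidin-1-yl for the whole (2-fluorophenyl)amino group, whereas this one keeps the amine nitrogen and changes only the ring on it, so a six-membered carbon ring at this position is not enough on its own to keep the measurable inhibition of compound 2. Compound 1 and compound 3 both end at a limit of the assay, so the step between them cannot be read and the two cannot be ranked: the limit of > 16000 nM in this assay, at which 2 of the 3 values shown sit.

The compounds shown leave open whether the aromatic ring alone accounts for the difference or whether the fluorine also counts, and a plain phenyl on the same amine nitrogen would separate the two. Also open, on these data alone, is how the result would change with chlorine in place of fluorine, or with a pyridyl ring in place of the 2-fluorophenyl.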